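This account rests on a few compounds, and the source may have more. Where it says the series, first, only, none or still open, it means among the compounds named here.

Measured compounds:
Compound 1 `CCc1c[nH]c(-c2nn(Cc3ccccc3F)c3ncccc23)n1`: 600 nM in a functional assay (aorta) with Oryctolagus cuniculus as the target; a higher number here means a weaker inhibitor, a lower number a stronger inhibitor
Compound 2 `Fc1ccccc1Cn1nc(-c2ccccn2)c2cccnc21`: 4800 nM in this assay
Compound 3 `Cc1cnc(-c2nn(Cc3ccccc3F)c3ncccc23)nc1N`: 675000 nM in this assay

Compound 3 gives the highest number of the three in this assay. Its nearest neighbour is compound 2, by a 140-fold higher number from compound 2 to compound 3 (2.15 log units; beyond the scatter), and the furthest is compound 1, by a 1100-fold higher number from compound 1 to compound 3 (3.05 log units; beyond the scatter). Both of these steps, and also an 8.0-fold higher number from compound 1 to compound 2 (0.90 log units; beyond the scatter), exchange the whole aromatic group attached to the shared core, and in each of them compound 3 sits at the weak end.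

Compound 4 `Nc1nc(-c2nn(Cc3ccccc3F)c3ncccc23)ncc1C1CCC1` keeps the aromatic group of compound 3 and alters only one substituent on it: cyclobutyl in place of methyl on an aromatic carbon. For the measured compounds named here, none of the measured steps changes this substituent; they all replace the entire ring, so nothing here reports what a larger group at this position does. Going by the values given here, the step from compound 3 to compound 4 therefore has no direct precedent, and the expectation can only be that the number in this assay stays in the weak region of compound 3, with a change no larger than modest in either direction.

Compound 4 is estimated at 350000 nM in this assay, within a range of 60000 nM to 2000000 nM, which means an expected step of a 1.9-fold lower number from compound 3 to compound 4 (0.29 log units; within the scatter).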

Compound 4, half-maximal inhibitory concentration: 633000 nM
Beside the measured number, compound 4's estimate is 1.8-fold (0.26 log units) below it, and the stated range covers the measured number.
By their numbers in this assay, from the lowest: compound 1; then compound 2; then compounds 4 and 3 (each within the scatter of the next).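

In this assay, the carbon ortho to an amino group and para to a large group takes cyclobutyl in place of methyl with a 1.1-fold lower number from compound 3 to compound 4 (0.03 log units; within the scatter), so this step, the only one that alters this substituent alone, does not separate the two compounds. Going from methyl, with 1 heavy atom and no ring, to cyclobutyl, with 4 heavy atoms and a four-membered ring, therefore does nothing measurable here to the large gaps that came with replacing the entire aromatic group, such as a 1100-fold higher number from compound 1 to compound 3 (3.05 log units; beyond the scatter) and a 140-fold higher number from compound 2 to compound 3 (2.15 log units; beyond the scatter). No measurement at hand offers an explanation for why these two groups read alike.

On these data alone, whether a different kind of group on this carbon, such as a carboxylic acid or a hydroxymethyl group, would shift the number remains open, since methyl and cyclobutyl are both plain carbon groups. Also open, as far as these compounds go, is what the amino group on this ring contributes to the weak numbers of compound 3 and compound 4, for instance whether a methoxy group in its place would give a different result.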